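Carbonyl substituent variation in a potassium channel binding series

This account rests on a few compounds, and the source may have more. Where it says the series, first, only, none or still open, it means among the compounds named here.

Three compounds share the core of compound 3 `O=C(Nc1c(C(O)(C(F)(F)F)C(F)(F)F)ccc2ccccc12)c1cccc(C(F)(F)F)c1` and differ only in the group on the carbonyl carbon. In an assay on LtK cells with ATP-sensitive inward rectifier potassium channel 11 (Homo sapiens) as the target (a lower number here means that less compound is needed, a higher number that more compound is needed for the effect), compound 1 `CCCC(C)C(=O)Nc1c(C(O)(C(F)(F)F)C(F)(F)F)ccc2ccccc12` gives only a limit, > 10000 nM. Compound 2 `O=C(Nc1ccc(Cl)cc1)Nc1c(C(O)(C(F)(F)F)C(F)(F)F)ccc2ccccc12` gives 276 nM and compound 3 gives 84 nM. The steps of an at least 36-fold lower number from compound 1 to compound 2 (1.55 log units; beyond the scatter) and an at least 110-fold lower number from compound 1 to compound 3 (2.07 log units; beyond the scatter) are both large, and both rest on the limit (the limit of > 10000 nM in this assay, at which 1 of the 3 values shown sits). The step of a 3.3-fold lower number from compound 2 to compound 3 (0.52 log units; beyond the scatter) is modest. Compound 3 therefore holds the lowest of the two measured numbers, with compound 2 the nearest.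

Compound 4 `COc1ccc(C(=O)Nc2c(C(O)(C(F)(F)F)C(F)(F)F)ccc3ccccc23)cc1` differs from compound 3 in one place: 4-methoxyphenyl in place of 3-(trifluoromethyl)phenyl on a carbonyl carbon. Within the data shown here, no measured step exchanges one substituent on an aryl ring for another; the only step between two aryl-bearing compounds, a 3.3-fold lower number from compound 2 to compound 3 (0.52 log units; beyond the scatter), alters the link to the carbonyl rather than the ring substituent. An aryl group on the carbonyl is retained in compound 4, so the large gain seen in an at least 110-fold lower number from compound 1 to compound 3 (2.07 log units; beyond the scatter) is expected to be largely kept, with at most a modest shift in either direction, or none beyond the scatter. Compound 4 is expected to give 200 nM in this assay, within a range of 60 nM to 700 nM. This estimate implies a step of a 2.4-fold higher number from compound 3 to compound 4 (0.38 log units; beyond the scatter).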

Compound 4, half-maximal effective concentration: 417 nM
Beside the measured number, compound 4's estimate is 2.1-fold (0.32 log units) below it, and the stated range covers the measured number.
By their numbers in this assay, from the lowest: compound 3; then compounds 2 and 4 (each within the scatter of the next). At a limit, above all of these: compound 1.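

In this assay, among these compounds, the step of a 5.0-fold higher number from compound 3 to compound 4 (0.70 log units; beyond the scatter) is the first measured exchange of one aryl group for another on this carbonyl carbon, so the number here depends on which aryl group is present and not only on having an aryl group in place of 1-methylbutyl. The step of a 1.5-fold higher number from compound 2 to compound 4 (0.18 log units; within the scatter) lies within the scatter, so 4-methoxyphenyl and (4-chlorophenyl)amino on this carbon cannot be told apart in this assay, and the gain of compound 3 over compound 2 is not a general property of aryl groups joined directly to the carbonyl. The step of an at least 23-fold lower number from compound 1 to compound 4 (1.37 log units; beyond the scatter) is large and shows that a second directly joined aryl group also gives a number far from that of compound 1, but it rests on a limit, that of compound 1: the limit of > 10000 nM in this assay, at which 1 of the 4 values shown sits.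

3-(Trifluoromethyl)phenyl and 4-methoxyphenyl differ in both the substituent and its numbered place on the ring, so the compounds shown cannot say which of the two carries the step; 4-(trifluoromethyl)phenyl and 3-methoxyphenyl would separate them. From the compounds shown here alone, whether unsubstituted phenyl or a saturated ring such as cyclohexyl would keep the number near those of the aryl compounds also stays open.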